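Methoxy for methyl on the arylamino group

The compounds below may be only part of what the source reports. "The series", "measured", "known", "first", "only" and "open" are said of these compounds alone.

Measured compounds:
compound 1, `FC(F)(F)c1ccc(CSc2nc(N3CCCCC3)c3ccccc3n2)cc1`, gives 28400 nM in a functional assay on MDA-MB-231 cells (Homo sapiens) for cytotoxicity, read by MTT assay, with a stated time of 72 h; a higher number here means a weaker inhibitor, a lower number a stronger inhibitor
compound 2, `Cc1ccc(Nc2nc(SCc3ccc(C(F)(F)F)cc3)nc3ccccc23)cc1`, gives > 50000 nM in this assay

For compound 2 this assay reports only a limit, > 50000 nM, not a number. For the measured compounds named here, the single measured step in the set is an at least 1.7-fold higher number from compound 1 to compound 2 (0.24 log units; that floor lies within the scatter); its size is open at the top, and it rests on (the limit of > 50000 nM in this assay, at which 1 of the 2 values shown sits).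

Compound 3, `COc1ccc(Nc2nc(SCc3ccc(C(F)(F)F)cc3)nc3ccccc23)cc1`, differs from compound 2 by methoxy in place of methyl on an aromatic carbon. Going by the values given here, no measured step touches this substituent: the one step recorded exchanges the whole amine group on the shared core, not a group on the 4-methylphenyl ring. It therefore gives no direction for the methyl-to-methoxy exchange, and nothing in the set points to a change beyond the scatter. Compound 2 sits at the limit, so compound 3 is expected to stay near the same place, with the estimated step of a number no higher from compound 2 to compound 3 (the limit leaves the size open) counted as no more than scatter. Compound 3 is estimated at 50000 nM, expected between 20000 nM and 120000 nM, most likely again reported only as a limit.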

Compound 3, half-maximal inhibitory concentration: 15700 nM
For compound 3 the middle estimate is 3.2-fold (0.50 log units) above the measured one, and the stated range ends above it.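

In this assay, the substituent on the arylamino ring matters: methoxy in place of methyl on this aromatic carbon gives an at least 3.1-fold lower number from compound 2 to compound 3 (0.50 log units; beyond the scatter). Going by these compounds, the true size of this step stays open, since compound 2 is reported only as a limit and the step is a floor: the limit of > 50000 nM in this assay, at which 1 of the 3 values shown sits. Exchange of piperidin-1-yl for (4-methoxyphenyl)amino on the shared core gives a 1.8-fold lower number from compound 1 to compound 3 (0.26 log units; within the scatter), so this pair does not separate the two amine groups, even though the methyl-to-methoxy change alone is beyond the scatter.

With only methyl and methoxy shown at this place, it remains open whether a hydroxyl, a chlorine or a dimethylamino group on the same aromatic carbon would give a similar or a larger step in this assay. On these data alone, all three compounds also keep the trifluoromethyl group, so it remains open how a nitrile there would read, and whether the methoxy step would hold with that change.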